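A Second Methoxy on the Pendant Ring

This account rests on a few compounds, and the source may have more. Where it says the series, first, only, none or still open, it means among the compounds named here.

Compound 1, `CCOC(=O)[C@@H]1CC(=O)c2sccc2[C@H]1c1ccc(OC)cc1`, and compound 2, `CCOC(=O)[C@@H]1CC(=O)c2sccc2[C@H]1c1ccccc1OC`, share one core and differ only in the pendant ring. In a physicochemical assay, read by spectrophotometry, with a stated time of 20 min, tested at 60 ug/mL (a higher number here means a stronger effect of the compound at the concentration tested, a lower number a weaker effect), compound 1 gives 20.3%, and compound 2 gives 17.8%. Compound 2 holds the lower of the two numbers, yet the gap to compound 1 lies within the scatter, so the two compounds are not separated by this assay. The next compound, compound 3, `CCOC(=O)[C@@H]1CC(=O)c2sccc2[C@H]1c1ccc(OC)cc1OC`, is built from compound 2 by a single change: methoxy in place of hydrogen on an aromatic carbon. Within the data shown here, no measured pair here shows what such a change does on its own, so there is no step to lean on; the only guide is that compound 1 and compound 2, which differ only in the pendant ring, come out alike. On that ground the step of a number 1.2 percentage points higher from compound 2 to compound 3 (within the scatter) is expected to stay within the scatter. Compound 3 is estimated at 19%, with a range from 8% to 32%.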

Compound 3, a percentage reported as activity, at one concentration (the size of the read-out at that concentration, not a potency): 15%
Estimate against measurement, compound 3: 4 percentage points above; the measured number falls inside the stated range.
By their numbers in this assay, from the lowest: compounds 3, 2 and 1 (each within the scatter of the next).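

Compound 3 carries the methoxy groups of compound 1 and compound 2 together, so the change can now be read from two directions in this assay: a number 2.8 percentage points lower from compound 2 to compound 3 (within the scatter) when methoxy enters on the aromatic carbon para to a large group, and a number 5.3 percentage points lower from compound 1 to compound 3 (within the scatter) when it enters on the other ring carbon that differs between the two. Both steps stay within the scatter, so a second methoxy on the pendant ring does not separate compound 3 from either parent in this assay. Nothing here accounts for the result.

As far as these compounds go, it remains open whether a different group at this place, such as an amine or a carboxylic acid, would shift the number beyond the scatter. The compounds shown also leave open whether a change away from the pendant ring, such as a carboxylic acid in place of the ethyl ester, would do so.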